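The compounds below may be only part of what the source reports. "The series", "measured", "known", "first", "only" and "open" are said of these compounds alone.

Compound 1 `C=C1[C@H](C)CCC[C@]1(C)CC/C(C)=C/CC1=C(O)C(=O)C=C(N[C@@H](C(=O)O)[C@H](C)O)C1=O`, compound 2 `C=C1[C@H](C)CCC[C@]1(C)CC/C(C)=C/CC1=C(O)C(=O)C=C(N[C@H](C(=O)O)C(C)C)C1=O` and compound 3 `CC1=CCC[C@](C)(CC/C(C)=C/CC2=C(O)C(=O)C=C(N[C@H](C(=O)O)C(C)C)C2=O)[C@@H]1C` were examined in an ADME assay on L1210 cells (Mus musculus) for cytotoxicity, with a stated time of 48 h; on this read-out higher numbers stand for weaker inhibition and lower numbers for stronger inhibition. In this assay compound 1 gives 4.6 ug/mL, compound 2 gives 4.4 ug/mL, and compound 3 gives 3.4 ug/mL. Going by the values given here, compound 1 and compound 2 share a core and differ only in the group on the amine nitrogen, (1-carboxy-2-hydroxypropyl in place of 1-carboxy-2-methylpropyl on an amine nitrogen); that step, a 1.0-fold higher number from compound 2 to compound 1 (0.02 log units; within the scatter), is as good as no step at all. Compound 2 and compound 3 carry the same group on that nitrogen but have different cores, (a group of 9 heavy atoms (9 carbon; one six-membered non-aromatic ring of carbon only) in place of a group of 9 heavy atoms (9 carbon; one six-membered non-aromatic ring of carbon only), on a saturated chain carbon, two bonds along the chain from a double-bonded chain carbon); the step of a 1.3-fold lower number from compound 2 to compound 3 (0.11 log units; within the scatter) is small as well. Compound 4 `CC1=CCC[C@](C)(CC/C(C)=C/CC2=C(O)C(=O)C=C(N[C@@H](C(=O)O)[C@H](C)O)C2=O)[C@@H]1C` combines the core of compound 3 with the group of compound 1 on the amine nitrogen, so the change 1-carboxy-2-hydroxypropyl in place of 1-carboxy-2-methylpropyl on an amine nitrogen is the same change already seen from compound 2 to compound 1, at the same place. Because a 1.0-fold higher number from compound 2 to compound 1 (0.02 log units; within the scatter) left the number essentially unchanged, the step of a 1.0-fold higher number from compound 3 to compound 4 (0.01 log units; within the scatter) is expected to be equally small. Compound 4 is therefore estimated to give 3.5 ug/mL, most likely falling between 2 ug/mL and 6.5 ug/mL.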

Compound 4, half-maximal inhibitory concentration: > 10 ug/mL
Compound 4 gave a limit, no number (the forecaster's own chance of this, stated with the estimate: 2%); middle value at least 2.8-fold (0.45 log units) away from the limit.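

In this assay compound 4 gives > 10 ug/mL, which is a limit of the assay and not a number. The change to 1-carboxy-2-hydroxypropyl on the amine nitrogen made almost no difference on one core but gave an at least 2.9-fold higher number from compound 3 to compound 4 (0.46 log units; beyond the scatter) on the other, so in this series its effect did not carry over unchanged: the same change on two cores in this assay, a 1.0-fold higher number (0.02 log units; within the scatter) from compound 2 to compound 1 and an at least 2.9-fold higher number (0.46 log units; beyond the scatter) from compound 3 to compound 4, at least 2.8-fold (0.44 log units) apart, beyond the scatter of two such steps The core change, an at least 2.1-fold higher number from compound 1 to compound 4 (0.33 log units; beyond the scatter), likewise depends on the group on the nitrogen, but these steps give only a minimum size, and the pairs do not show why the two cores part: the same change on two cores in this assay, a 1.3-fold lower number (0.11 log units; within the scatter) from compound 2 to compound 3 and an at least 2.1-fold higher number (0.33 log units; beyond the scatter) from compound 1 to compound 4, at least 2.8-fold (0.44 log units) apart, beyond the scatter of two such steps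

The compounds shown leave open whether the same split appears with other groups on the amine nitrogen, such as 1-carboxyethyl or a methyl ester in place of the carboxylic acid. They also leave open how a third core, for instance one with a longer chain, would respond to this change.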